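Fluorophenyl ring replaces the chlorohexyl urea chain

The source may hold more compounds than are shown below. What is called first, only, known or untested is meant among the compounds shown, and "the series" means these compounds.

Among the measured compounds shown here, in an assay on LtK cells with ATP-sensitive inward rectifier potassium channel 11 (Homo sapiens) as the target (a lower number here means that less compound is needed, a higher number that more compound is needed for the effect), compound 3 `O=C(NCCCCCCCl)Nc1c(C(O)(C(F)(F)F)C(F)(F)F)ccc2ccccc12` gives 4840 nM, the highest of the three numbers known so far. Compound 1 `O=C(Nc1c(C(O)(C(F)(F)F)C(F)(F)F)ccc2ccccc12)C1CCC1` gives 45 nM and compound 2 `O=C(Nc1c(C(O)(C(F)(F)F)C(F)(F)F)ccc2ccccc12)C1CCCC1` gives 495 nM. Compound 4 `O=C(Nc1c(C(O)(C(F)(F)F)C(F)(F)F)ccc2ccccc12)c1ccc(F)cc1` differs from compound 3 by 4-fluorophenyl in place of (6-chlorohexyl)amino on a carbonyl carbon. For the measured compounds named here, two measured steps bear on this change: a 110-fold higher number from compound 1 to compound 3 (2.03 log units; beyond the scatter) and a 9.8-fold higher number from compound 2 to compound 3 (0.99 log units; beyond the scatter). Going by the values given here, both put the (6-chlorohexyl)amino group in place of a ring and gave a much higher number, so the reverse exchange, a ring in place of that chain, points toward a large drop, although no measured compound carries 4-fluorophenyl. Compound 4 is therefore expected to give about 200 nM, with a range from 40 nM to 1000 nM. The expected step is a 24-fold lower number from compound 3 to compound 4 (1.38 log units; beyond the scatter).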

Compound 4, half-maximal effective concentration: 70 nM
Compound 4: middle estimate off by 2.9-fold (0.46 log units), on the high side; the measured number falls inside the stated range.
By their numbers in this assay, from the lowest: compounds 1 and 4 (each within the scatter of the next); then compound 2; then compound 3.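

A ring on this carbonyl carbon need not be saturated: 4-fluorophenyl in place of the chain gives a 69-fold lower number from compound 3 to compound 4 (1.84 log units; beyond the scatter) and in place of cyclopentyl gives a 7.1-fold lower number from compound 2 to compound 4 (0.85 log units; beyond the scatter). Set against cyclobutyl, it gives a 1.6-fold higher number from compound 1 to compound 4 (0.19 log units; within the scatter), so these two rings cannot be told apart in this assay. Nothing measured here explains these steps.

On these data alone, it remains open whether the fluorine contributes, which a plain phenyl ring would test. Also open, as far as these compounds go, is whether a cyclopropyl ring or a shorter amine chain would be tolerated at this carbonyl carbon.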